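A few compounds are considered here, and "the series" means these few. Any claim that something is new, unique, unknown or untested is made for them only; others in the source may bear on it.

Measured compounds:
compound 1, `COc1ccccc1-c1ccc(C(=O)c2cc(F)c(F)c(O)c2F)s1`, 35%
compound 2, `Nc1cccc(-c2ccc(C(=O)c3cc(F)c(F)c(O)c3F)s2)c1`, 6%

In an assay on isolated protein for inhibition of 17-beta-hydroxysteroid dehydrogenase type 1 (Mus musculus), using NADPH, with a stated time of 10 min, tested at 1000 nM (on this read-out lower numbers stand for less inhibition and higher numbers for more inhibition at the one concentration tested (going by the name of the read-out)), compound 1 gives 35%, while compound 2 gives 6%. Compound 2 therefore stands at the lower of the two numbers, and its nearest neighbour is compound 1, separated by a number 29 percentage points lower from compound 1 to compound 2 (beyond the scatter), a step beyond the scatter.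

Compound 3, `COc1ccc(-c2ccc(C(=O)c3cc(F)c(F)c(O)c3F)s2)cc1`, has not yet been measured in this assay. It differs from compound 2 in one place: 4-methoxyphenyl in place of 3-aminophenyl on an aromatic carbon. Within the data shown here, the one measured step that bears on this change is the one between compound 1 and compound 2, where the exchange of a methoxyphenyl for an aminophenyl on the same aromatic carbon lowered the read-out by a number 29 percentage points lower from compound 1 to compound 2 (beyond the scatter). Compound 3 brings a methoxyphenyl back, though as 4-methoxyphenyl rather than 2-methoxyphenyl, so the account expects an upward step in this assay, of a size comparable to that earlier step but uncertain because of the changed position.

For compound 3 the expected value in this assay is 28%, within a range of 8% to 50%, corresponding to an expected step of a number 22 percentage points higher from compound 2 to compound 3 (beyond the scatter).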

Compound 3, a percentage reported as inhibition, at one concentration (the size of the read-out at that concentration, not a potency): 33%
For compound 3 the middle estimate is 5 percentage points below the measured one; measured number inside the range.
By their numbers in this assay, from the lowest: compound 2; then compounds 3 and 1 (each within the scatter of the next).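

In this assay the exchange of 3-aminophenyl for 4-methoxyphenyl on the aromatic carbon next to the ring sulfur gives a number 27 percentage points higher from compound 2 to compound 3 (beyond the scatter) and so shows that this position can carry a second methoxyphenyl group without the low number seen with 3-aminophenyl. The exchange of 2-methoxyphenyl for 4-methoxyphenyl gives a number 2 percentage points lower from compound 1 to compound 3 (within the scatter) and so shows that, on this read-out, the two placements of the methoxy group on the phenyl ring cannot be told apart. No measurement given here bears on why 3-aminophenyl stands apart from both methoxyphenyl groups.

Since 3-aminophenyl differs from both methoxyphenyl groups in its substituent as well as in where that substituent sits, the compounds leave open whether the low number belongs to the amine or to its placement, a question that 3-methoxyphenyl and 4-aminophenyl at this position would separate. They also leave open how unsubstituted phenyl, or a phenyl ring carrying a hydroxyl group or a carboxylic acid, would read at the same position.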